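Methyl for methoxy on a scaffold at the limit

A few compounds are considered here, and "the series" means these few. Any claim that something is new, unique, unknown or untested is made for them only; others in the source may bear on it.

Compound 2 `COc1ccc2c(c1)SC(C(=O)O)CC(c1ccc(F)cc1C)=N2` gives in a functional assay on HL-60 cells (Homo sapiens), read by MTT assay, with a stated time of 72 h (on this read-out higher numbers stand for weaker inhibition of growth and lower numbers for stronger inhibition of growth), only a limit, > 10000000 nM, so where it stands on the numbers shown is known only as a bound. Compound 1 `Cc1cc(F)ccc1C1=Nc2ccc(Cl)cc2SC(C(=O)O)C1` likewise gives in this assay a limit, > 10000000 nM. The step that the two limits leave unreadable from compound 1 to compound 2 stays unreadable, as both values sit at the limit of > 10000000 nM in this assay, at which 2 of the 2 values shown sit. Compound 3 `Cc1ccc2c(c1)SC(C(=O)O)CC(c1ccc(F)cc1C)=N2` differs from compound 2 by methyl in place of methoxy on an aromatic carbon. Within the data shown here, no measured step bears on this change, and no direction can be read. Compound 3 is expected near the same limit, estimated at 10000000 nM (range 2000000 nM to 50000000 nM). The expected step of a number no higher from compound 2 to compound 3 (the limit leaves the size open) lies within the scatter.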

Compound 3, concentration for 50% growth inhibition: > 10000000 nM
Compound 3: a limit, no number; the forecaster's own chance of this, stated with the estimate: 85%; the middle value sits exactly at the limit.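

No new step can be read among compound 1, compound 2 and compound 3, since each value is a limit and not a number: the limit of > 10000000 nM in this assay, at which 3 of the 3 values shown sit.

The compounds shown leave open how chloro, methoxy and methyl on this aromatic carbon compare in this assay.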